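Swapping Chloro for Fluoro on the Fused Ring

The source may report more compounds than this note shows. Statements on the series, on what has been measured and on what is new or still open speak of the compounds shown alone.

Compound 1 `COc1ccc(S(=O)(=O)c2cnc3cc(F)ccc3c2-c2ccc(Cl)cc2)cc1`: 1.28 mL/min
Compound 2 `O=S(=O)(c1ccc(F)c(F)c1)c1cnc2cc(F)ccc2c1-c1ccc(Cl)cc1`: 0.01 mL/min
Compound 3 `O=S(=O)(c1ccc(F)cc1)c1cnc2cc(Cl)ccc2c1-c1ccc(Cl)cc1`: 0.21 mL/min

Of the compounds shown here, three have been measured in an ADME assay on microsomes from liver (Homo sapiens) for metabolic stability, tested at 2.5 uM; on this read-out lower numbers stand for slow clearance and higher numbers for fast clearance. Compound 3 stands second highest of the three: compound 1 gives a higher number and compound 2 a lower one, both gaps beyond the scatter. Compound 4 `O=S(=O)(c1ccc(F)cc1)c1cnc2cc(F)ccc2c1-c1ccc(Cl)cc1` differs from compound 3 by fluoro in place of chloro on an aromatic carbon. Among the compounds with values here, the only single-site step measured so far is a 130-fold lower number from compound 1 to compound 2 (2.11 log units; beyond the scatter), which is large but concerns the group on the sulfonyl sulfur, not the fused ring, so it does not bear directly on this change. Compound 2 carries the same fluoro on the fused ring as compound 4, yet it also carries a different group on the sulfonyl sulfur, so its number cannot be read as a template for compound 4. Within the data shown here, with no matching step to lean on, the change is expected to shift the number only modestly. Compound 4 is therefore estimated at 0.15 mL/min, with a range from 0.05 mL/min to 0.5 mL/min. The step this estimate implies, a 1.4-fold lower number from compound 3 to compound 4 (0.15 log units; within the scatter), is expected to remain within the scatter.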

Compound 4, intrinsic clearance in a liver preparation (reported as CLH), per the amount of preparation that the assay uses: 1.23 mL/min
For compound 4 the middle estimate is 8.2-fold (0.91 log units) below the measured one; the whole stated range lies below it.
By their numbers in this assay, from the lowest: compound 2; then compound 3; then compounds 4 and 1 (each within the scatter of the next).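

In this assay fluoro in place of chloro on the fused ring is no neutral swap (a 5.9-fold higher number from compound 3 to compound 4 (0.77 log units; beyond the scatter)). On the ring carried by the sulfonyl sulfur, hydrogen in place of fluoro gives a large step (a 120-fold higher number from compound 2 to compound 4 (2.09 log units; beyond the scatter)), whereas fluoro in place of methoxy stays within the scatter (a 1.0-fold lower number from compound 1 to compound 4 (0.02 log units; within the scatter)). The large step between compound 1 and compound 2 therefore tracks the extra fluoro on that ring rather than the loss of methoxy.

On these data alone, only chloro and fluoro appear at the fused-ring position here, so it remains open how hydrogen, methyl or a nitrile there would read, or whether the chloro and fluoro gap would persist with another group on the sulfonyl sulfur. Nothing measured here explains any of these steps.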